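The source may hold more compounds than are shown below. What is called first, only, known or untested is meant among the compounds shown, and "the series" means these compounds.

Working notes on the series. For the measured compounds named here, compound 3 `CC1=C(C(=O)C2CC2)C(c2ccco2)NC(=O)N1` gives 2% in an assay on membranes from CHO cells for displacement of a labelled ligand from adenosine receptor A1 (Homo sapiens), read by scintillation counting, with a stated time of 60 min, tested at 1 uM (on this read-out lower numbers stand for less inhibition and higher numbers for more inhibition at the one concentration tested (going by the name of the read-out)), the lowest of the three numbers so far, though within the scatter of both others: compound 1 `COC(=O)C1=C(C)NC(=O)NC1c1ccoc1` gives 8% and compound 2 `CC1=C(C(=O)OC(C)(C)C)C(c2ccoc2)NC(=O)N1` gives 11%. Going by the values given here, the only measured step, a number 3 percentage points higher from compound 1 to compound 2 (within the scatter), alters a different part of the shared core and does not touch the furan-2-yl group, so no measured step bears directly on the change to compound 4 `CC1=C(C(=O)C2CC2)C(c2ccoc2)NC(=O)N1`: furan-3-yl in place of furan-2-yl on a saturated ring carbon. Among the compounds with values here, with all three measured compounds low on this read-out and no relevant precedent, no step beyond the scatter is expected; the expected step is a number 3 percentage points higher from compound 3 to compound 4 (within the scatter). Compound 4 is therefore estimated at 5%, with a range from 0% to 15%.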

Compound 4, a percentage reported as inhibition, at one concentration (the size of the read-out at that concentration, not a potency): 1%
Estimate against measurement, compound 4: 4 percentage points above, and the stated range covers the measured number.
By their numbers in this assay, from the lowest: compounds 4, 3, 1 and 2 (each within the scatter of the next).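

The step of a number 1 percentage points lower from compound 3 to compound 4 (within the scatter) in this assay shows that, with the cyclopropylcarbonyl group in place, furan-3-yl and furan-2-yl are not told apart on this saturated ring carbon at the one concentration tested. With furan-3-yl held, the steps of a number 10 percentage points lower from compound 2 to compound 4 (within the scatter) and a number 7 percentage points lower from compound 1 to compound 4 (within the scatter) show the same for cyclopropyl against tert-butoxy and methoxy on the carbonyl carbon. No available evidence explains these numbers.

Open, on these data alone, is whether an amine or a carboxylic acid on the furan, or a longer chain on the carbonyl carbon, would give a step beyond the scatter.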